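The source may report more compounds than this note shows. Statements on the series, on what has been measured and on what is new or still open speak of the compounds shown alone.

Measured so far in a functional assay on A549 cells (Homo sapiens) for antiproliferative activity, read by MTT assay, with a stated time of 24 h; a lower number here means a stronger inhibitor, a higher number a weaker inhibitor:

Compound 1 `COc1cc(-c2cc(C(=O)/C=C/c3ccc(Cl)cc3)nc3cc(-c4ccccc4)nn23)cc(OC)c1OC` gives 23800 nM.
Compound 2 `COc1ccc(-c2cc(C(=O)/C=C/c3ccc(C)cc3)nc3cc(-c4ccccc4)nn23)cc1OC` gives 22200 nM.
Compound 3 `COc1ccc(/C=C/C(=O)c2cc(-c3cc(OC)c(OC)c(OC)c3)n3nc(-c4ccccc4)cc3n2)cc1` gives 21200 nM.

Compound 3 has the lowest of these three numbers in this assay, but its gaps to compound 1 and compound 2 are both within the scatter, so the three cannot be told apart. Compound 4 `COc1cc(-c2cc(C(=O)/C=C/c3ccc(C)cc3)nc3cc(-c4ccccc4)nn23)cc(OC)c1OC` differs from compound 3 by one change: methyl in place of methoxy on an aromatic carbon. For the measured compounds named here, the one measured step at the same aromatic carbon, a 1.1-fold lower number from compound 1 to compound 3 (0.05 log units; within the scatter), changed nothing beyond the scatter, and compound 2, which also carries a methyl there, sits at the same level. No step beyond the scatter is therefore expected from compound 3 to compound 4 in this assay, with a 1.0-fold higher number from compound 3 to compound 4 (0.02 log units; within the scatter). Compound 4 is expected to give about 22000 nM, in a range from 11000 nM to 44000 nM.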

Compound 4, half-maximal inhibitory concentration: 20000 nM
Compound 4: the middle estimate sits 1.1-fold (0.04 log units) above what was measured; measured number inside the range.
By their numbers in this assay, from the lowest: compounds 4, 3, 2 and 1 (each within the scatter of the next).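

At this position on the aromatic ring, methyl, methoxy and chloro now read alike in this assay: methyl in place of methoxy gives a step within the scatter (a 1.1-fold lower number from compound 3 to compound 4 (0.03 log units; within the scatter)), as does methyl in place of chloro (a 1.2-fold lower number from compound 1 to compound 4 (0.08 log units; within the scatter)). An added methoxy elsewhere on the shared core also stays within the scatter (a 1.1-fold lower number from compound 2 to compound 4 (0.05 log units; within the scatter)). Nothing available explains this flat result. From the compounds shown here alone, whether an amine, a carboxylic acid or a longer chain such as butoxy at this position would shift the number beyond the scatter remains open.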